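Extending the Urea Substituent of Compound 1

This account rests on a few compounds, and the source may have more. Where it says the series, first, only, none or still open, it means among the compounds named here.

Compound 1 `COc1ccc(-c2ccc(CN(CCC3CCN(Cc4ccc(C)cc4)CC3)C(=O)NC(C)C)cc2)cc1` stands higher of the two measured compounds: in an in vitro functional assay on HEK293 cells for antagonist activity at melanin-concentrating hormone receptor 1 (Homo sapiens), read by GTPgammaS binding, with a stated time of 45 min (on this read-out lower numbers stand for lower potency and higher numbers for higher potency (the scale is a negative logarithm)), compound 1 gives 6.34. Its companion, compound 2 `Cc1ccc(CN2CCC(CCN(Cc3ccc(-c4cccc(C#N)c4)cc3)C(=O)NC(C)C)CC2)cc1`, gives 6 in this assay, and the step of a number 0.34 log units lower from compound 1 to compound 2 (beyond the scatter) comes from exchanging one aromatic substituent, 3-cyanophenyl in place of 4-methoxyphenyl on an aromatic carbon. Compound 3 `COc1ccc(-c2ccc(CN(CCC3CCN(Cc4ccc(C)cc4)CC3)C(=O)NC(C)(C)COC(C)=O)cc2)cc1` keeps the aromatic part of compound 1 unchanged and differs at the other end of the molecule: acetoxymethyl in place of hydrogen on a saturated chain carbon bound to an amide-type nitrogen and two saturated chain carbons. Within the data shown here, no measured step touches this part of the structure, so the single known step, which concerns a different region and was modest, offers no direct guide. With nothing pointing either way, the expected step of a number 0.14 log units lower from compound 1 to compound 3 (within the scatter) is small, within the scatter of repeated measurements. Compound 3 is therefore expected to give 6.2 in this assay, estimated to lie between 5.6 and 6.8.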

Compound 3, negative logarithm of the antagonist equilibrium constant: 6.19
Compound 3: the middle estimate sits 0.01 log units above what was measured; low and high end bracket the measured number.
By their numbers in this assay, from the lowest: compounds 2, 3 and 1 (each within the scatter of the next, the first and the last beyond it).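

Acetoxymethyl in place of hydrogen on a saturated chain carbon bound to an amide-type nitrogen and two saturated chain carbons gives a number 0.15 log units lower from compound 1 to compound 3 (within the scatter) in this assay. The earlier step concerned only the aromatic end of the molecule, whereas this one shows that, at the urea end, isopropyl can become 1-(acetoxymethyl)-1-methylethyl, with 5 heavy atoms entering, and the number stays within the scatter of that of compound 1. No measurement available here explains this result.

As far as these compounds go, whether the ester itself matters stays open, since a hydroxymethyl, an aminomethyl or a carboxylic acid on the same carbon could give a different number. From the compounds shown here alone, how much further this end can grow is also open, for example with a longer chain or a ring carrying an amine.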